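The compounds below may be only part of what the source reports. "The series", "measured", "known", "first", "only" and "open" are said of these compounds alone.

Of the compounds shown here, two have been measured in an assay on HEK293 cells for antagonist activity at P2X purinoceptor 7 (Homo sapiens), read by fluorescence, with a stated time of 2 h; on this read-out higher numbers stand for weaker inhibition and lower numbers for stronger inhibition. Compound 1 `O=C(NC1CC1)c1cccc(S(=O)(=O)Oc2ccc(-c3cncn3C3CCN(C(=O)c4ccc(Cl)c(C(F)(F)F)c4)CC3)cc2)c1` gives 88 nM, and compound 2 `COc1ccc(C(=O)N2CCC(n3cncc3-c3ccc(OS(=O)(=O)c4cccc5cnccc45)cc3)CC2)cc1OC` gives 259 nM. Of the two numbers, compound 2 thus has the higher one, and the gap to compound 1 is beyond the usual scatter of repeat measurements, so compound 2 is the weaker inhibitor of the pair on this assay.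

Compound 3 `N#Cc1ccc(C(=O)N2CCC(n3cncc3-c3ccc(OS(=O)(=O)c4cccc5cnccc45)cc3)CC2)cc1` shares the core of compound 2 and differs from it in a single place: 4-cyanophenyl in place of 3,4-dimethoxyphenyl on a carbonyl carbon. Among the measured compounds shown here, no pair of measured compounds shows this change, so its effect must be estimated. The two measured compounds differ in several places at once and offer no direct guide to this exchange of one aryl group for another on the same carbonyl carbon. A step of modest size is expected, and it may not exceed the scatter in either direction; the step from compound 2 to compound 3 is estimated at a 1.3-fold lower number from compound 2 to compound 3 (0.11 log units; within the scatter) in this assay. Compound 3 is therefore expected to give about 200 nM in this assay, within a range from 60 nM to 700 nM.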

Compound 3, half-maximal inhibitory concentration: 269 nM
The estimate for compound 3 lay 1.3-fold (0.13 log units) below the measured number; low and high end bracket the measured number.
By their numbers in this assay, from the lowest: compound 1; then compounds 2 and 3 (each within the scatter of the next).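

In this assay, among the compounds shown here, 4-cyanophenyl in place of 3,4-dimethoxyphenyl on a carbonyl carbon gives a 1.0-fold higher number from compound 2 to compound 3 (0.02 log units; within the scatter), the first step that isolates this position. Within the two compounds of this pair, the two aryl groups can therefore be exchanged with no change beyond the scatter, even though the methoxy-bearing ring is replaced by a smaller group with a nitrile and one fewer hydrogen-bond acceptor. No independent measurement accounts for why these two groups read alike.

The compounds shown leave open whether this insensitivity extends beyond substituted phenyl groups on that carbonyl carbon, for example to a phenyl ring carrying a carboxylic acid or an amine, or to a longer chain in place of the aryl group. For the compounds shown here, they also leave open how much of the distance to compound 1 belongs to this position, since compound 1 differs from compound 2 and compound 3 in more than one place and no single step connects them.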